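This account rests on a few compounds, and the source may have more. Where it says the series, first, only, none or still open, it means among the compounds named here.

Measured so far, in a functional assay on K562 cells (Homo sapiens) for cytotoxicity, read by CCK-8 assay, with a stated time of 72 h; on this read-out lower numbers stand for stronger inhibition and higher numbers for weaker inhibition:
- compound 2 `C=CCn1c(=O)/c(=C\c2cccc(F)c2)[nH]c(=O)/c1=C\c1ccccc1OC` gives 4100 nM
- compound 3 `C=CCn1c(=O)/c(=C\c2ccccc2Cl)[nH]c(=O)/c1=C\c1ccccc1OC` gives 2500 nM
- compound 1 `COc1ccccc1/C=c1/[nH]c(=O)/c(=C\c2cccc(Cl)c2Cl)[nH]c1=O` is reported as "not active" (no number reported), with no number

Compound 3 holds the lowest of the two numbers, but its nearest neighbour is compound 2 and the step of a 1.6-fold lower number from compound 2 to compound 3 (0.21 log units; within the scatter) lies within the scatter, so the two cannot be ordered. Compound 4 `C=CCn1c(=O)/c(=C\c2ccc(Cl)c(Cl)c2)[nH]c(=O)/c1=C\c1ccccc1OC` differs from compound 3 by 3,4-dichlorophenyl in place of 2-chlorophenyl on a double-bonded chain carbon bound to an aromatic carbon. Going by the values given here, no measured step covers this change: compound 1 carries two chlorines on that ring but also differs elsewhere, so it bears only loosely. Compound 4 is therefore expected near compound 3, with the step of a 1.4-fold higher number from compound 3 to compound 4 (0.15 log units; within the scatter) not beyond the scatter, and an estimate of 3500 nM (range 1200 nM to 10000 nM).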

Compound 4, half-maximal inhibitory concentration: "not active" (no number reported)
Compound 4: no number reported, and the estimate cannot be compared.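

Going by these compounds alone, compound 4 is reported as "not active" (no number reported), so no step from compound 3 to compound 4 can be read. No evidence here bears on this result. The compounds shown leave open how far the number for compound 4 would lie from that of compound 3.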